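Replacing the nitrile of compound 3 with bromo

The source may hold more compounds than are shown below. What is called first, only, known or untested is meant among the compounds shown, and "the series" means these compounds.

Measured in an ADME assay on microsomes from liver (Canis lupus familiaris) for metabolic stability, with a stated time of 10 min; a higher number here means that more of the compound is left, a lower number that less of the compound is left:
- compound 1 `FC(F)(F)c1ccccc1-c1ccc2[nH]c(C3=NOC4(CCCCC4)C3)nc2c1`: 71%
- compound 2 `FC(F)(F)c1ccccc1-c1cc(Cl)c2[nH]c(C3=NOC4(CCCCC4)C3)nc2c1`: 100%
- compound 3 `N#Cc1cc(-c2ccccc2C(F)(F)F)cc2nc(C3=NOC4(CCCCC4)C3)[nH]c12`: 51%

Compound 3 stands lowest of the three at 51% in this assay, under both other compounds. The next compound to test is compound 4 `FC(F)(F)c1ccccc1-c1cc(Br)c2[nH]c(C3=NOC4(CCCCC4)C3)nc2c1`, which carries bromo in place of cyano on an aromatic carbon, ortho to a fused ring (bromo in place of cyano on an aromatic carbon).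

Among the measured compounds shown here, no bromo compound has been measured yet, so the closest evidence comes from chloro at the same place. The large a number 49 percentage points lower from compound 2 to compound 3 (beyond the scatter) runs from chloro to cyano, and the change here goes the opposite way. The modest a number 20 percentage points lower from compound 1 to compound 3 (beyond the scatter) and the modest a number 29 percentage points higher from compound 1 to compound 2 (beyond the scatter) both point the same way, with cyano under hydrogen and chloro over it. Bromo need not match chloro, and compound 2 at 100% already sits at the top of the scale.

A large upward step is therefore expected, and the estimated step is a number 39 percentage points higher from compound 3 to compound 4 (beyond the scatter). For compound 4 the estimated value is 90%, with an expected range from 70% to 100%.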

Compound 4, percent of the compound remaining: 74%
Estimate against measurement, compound 4: 16 percentage points above, within the range that was stated.
By their numbers in this assay, from the lowest: compound 3; then compounds 1 and 4 (each within the scatter of the next); then compound 2.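

In this assay the two halogens part at this position on the shared core, with a number 26 percentage points lower from compound 2 to compound 4 (beyond the scatter) on going from chloro to bromo, so the chloro result does not carry over to bromo. Bromo in place of the nitrile still gives a number 23 percentage points higher from compound 3 to compound 4 (beyond the scatter) here, while bromo in place of hydrogen gives a number 3 percentage points higher from compound 1 to compound 4 (within the scatter) and so no readable change, which leaves chloro and cyano as the only substituents shown to separate from hydrogen, in opposite directions. No measurement on hand accounts for the gap between chloro and bromo.

On these data alone, whether compound 2 is a lone high point remains open, and a methyl, a methoxy or an amine at this position would test that. As far as these compounds go, whether the same order holds without the 2-(trifluoromethyl)phenyl group also remains open.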